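Pyrazolyl in Place of Fluorophenyl: Expected Adenosine Binding

A few compounds are considered here, and "the series" means these few. Any claim that something is new, unique, unknown or untested is made for them only; others in the source may bear on it.

Compound 1 `CC(C)(C)Cc1c(-c2ccc(F)cc2)sc(N)c1C(=O)c1ccc(Cl)cc1`: 1%
Compound 2 `COCCOc1ccc(-c2sc(N)c(C(=O)c3ccc(Cl)cc3)c2CC(C)(C)C)cc1`: 1%
Compound 3 `CC(C)(C)Cc1c(Br)sc(N)c1C(=O)c1cccc(Cl)c1`: 1%

In an assay on CHO cells for displacement of a labelled ligand from adenosine receptor A1 (Homo sapiens), read by scintillation counting, tested at 10 uM (on this read-out higher numbers stand for more inhibition at the one concentration tested (going by the name of the read-out) and lower numbers for less inhibition), compound 1 gives 1%, level with compound 2 and compound 3 within the scatter. Among the measured compounds shown here, the only measured step that alters a single place, no change at the digits printed from compound 1 to compound 2 (within the scatter), left the read-out unchanged. Compound 4 `CC(C)(C)Cc1c(-c2cn[nH]c2)sc(N)c1C(=O)c1ccc(Cl)cc1` differs from compound 1 in one place: 1H-pyrazol-4-yl in place of 4-fluorophenyl on an aromatic carbon. For the measured compounds named here, no measured step mirrors this exchange; the step from compound 1 to compound 2 only altered a group on the 4-fluorophenyl rather than replacing the ring. Since all three measured compounds sit at essentially no inhibition, no movement beyond the scatter is expected, a number 2 percentage points higher from compound 1 to compound 4 (within the scatter). Compound 4 is therefore estimated to give 3%, within a range from -6% to 15%.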

Compound 4, a percentage reported as inhibition, at one concentration (the size of the read-out at that concentration, not a potency): 1%
For compound 4 the middle estimate is 2 percentage points above the measured one; the range from low to high includes it.
By their numbers in this assay, from the lowest: compounds 1, 2, 3 and 4 (each within the scatter of the next).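

In this assay, the whole ring on this aromatic carbon next to the ring sulfur is exchanged, not just a group on it: 1H-pyrazol-4-yl in place of 4-fluorophenyl gives no change at the digits printed from compound 1 to compound 4 (within the scatter). The entering ring brings a hydrogen-bond donor and acceptor that the leaving ring lacks, yet the reading stays level with the others, all near no inhibition. Nothing measured here accounts for this result. As far as these compounds go, whether a piperazine or a carboxylic acid on this carbon would move the reading beyond the scatter stays open. With every compound shown near no inhibition, none reveals what would raise it.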